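The source may hold more compounds than are shown below. What is called first, only, known or untested is meant among the compounds shown, and "the series" means these compounds.

Measured compounds in an ADME assay on liver for metabolic stability, with Liver microsome (Rattus norvegicus) as the target, read by LC-MS, using microsomes, with a stated time of 5 h; on this read-out higher numbers stand for fast clearance and lower numbers for slow clearance:
- compound 1 `O[C@H](c1ccccn1)[C@]1(c2ccc(C(F)(F)F)cc2)C[C@@H](O)C1`: 50 mL/min/kg
- compound 2 `O[C@H](c1ccccn1)C1(c2ccc(OC(F)(F)F)cc2)CCC1`: 1050 mL/min/kg
- compound 3 `OC(c1ncccn1)C1(c2ccc(OC(F)(F)F)cc2)CCC1`: 483 mL/min/kg

Compound 1 has the lowest number of the three; compound 3 sits well above it and compound 2 further still, both gaps beyond the scatter. Compound 2 and compound 3 carry a trifluoromethoxy group and lack the ring hydroxy present in compound 1, so neither gives a single-point step to it.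

Compound 4 `C[C@]1(O)C[C@@](c2ccc(C(F)(F)F)cc2)([C@H](O)c2ccccn2)C1` is the next step from compound 1: methyl in place of hydrogen on a saturated ring carbon. No comparable change has been measured in the series, so the expected step in this assay is small, with no direction beyond the scatter. For compound 4 the estimate is 45 mL/min/kg with a range of 15 mL/min/kg to 150 mL/min/kg, an expected step of a 1.1-fold lower number from compound 1 to compound 4 (0.05 log units; within the scatter).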

Compound 4, clearance: 150 mL/min/kg
For compound 4 the middle estimate is 3.3-fold (0.52 log units) below the measured one; measured number inside the range.
By their numbers in this assay, from the lowest: compound 1; then compound 4; then compound 3; then compound 2.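

In this assay, the series gains its first single-point step: methyl in place of hydrogen on a saturated ring carbon of the four-membered ring (a 3.0-fold higher number from compound 1 to compound 4 (0.48 log units; beyond the scatter)). This ring position is therefore not indifferent to substitution, since one added carbon moves clearance upward, beyond the scatter. No measurement on hand explains the rise.

From the compounds shown here alone, whether ethyl or fluoro at the same carbon would give a larger, smaller or reversed step remains open. So does whether the methyl step carries over to the trifluoromethoxy compounds.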